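This account rests on a few compounds, and the source may have more. Where it says the series, first, only, none or still open, it means among the compounds named here.

Measured compounds in an assay on isolated protein for inhibition of aldehyde dehydrogenase 1A1 (Homo sapiens), read by spectrophotometry, tested at 10 uM; on this read-out lower numbers stand for less inhibition and higher numbers for more inhibition at the one concentration tested (going by the name of the read-out):

Compound 1, `Cc1cccc(Cn2c(CN3CCN(C(=O)c4ccc(C(F)(F)F)cc4)CC3)nc3ccccc32)c1`, gives 22.9%.
Compound 2, `CCC(=O)N1CCN(Cc2nc3ccccc3n2Cc2cccc(C)c2)CC1`, gives 85.1%.
Compound 3, `Cc1ccc(C(=O)N2CCN(Cc3nc4ccccc4n3Cc3cccc(C)c3)CC2)cc1`, gives 64.9%.

Compound 3 stands second highest of the three: compound 2 lies a number 20.2 percentage points lower from compound 2 to compound 3 (beyond the scatter) in reverse, while compound 1 sits well beneath it, a number 42 percentage points higher from compound 1 to compound 3 (beyond the scatter).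

Compound 4, `Cc1cccc(Cn2c(CN3CCN(C(=O)C4CCC4)CC3)nc3ccccc32)c1`, is not yet measured. It differs from compound 3 in one place: cyclobutyl in place of 4-methylphenyl on a carbonyl carbon.

Among the compounds with values here, two measured steps bear on this. The step of a number 20.2 percentage points lower from compound 2 to compound 3 (beyond the scatter) shows that a 4-methylphenyl on the carbonyl carbon gives a modest loss against a small saturated ethyl. The step of a number 62.2 percentage points higher from compound 1 to compound 2 (beyond the scatter) shows a large gain when a 4-(trifluoromethyl)phenyl is replaced by ethyl. Cyclobutyl is a small saturated group like ethyl, so compound 4 is expected to move toward the number of compound 2, a step upward of roughly a number 13.1 percentage points higher from compound 3 to compound 4 (beyond the scatter). The estimate for compound 4 is 78%, with a range from 60% to 92%.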

Compound 4, a percentage reported as inhibition, at one concentration (the size of the read-out at that concentration, not a potency): 69.1%
The estimate for compound 4 lay 8.9 percentage points above the measured number; the range from low to high includes it.
By their numbers in this assay, from the lowest: compound 1; then compounds 3 and 4 (each within the scatter of the next); then compound 2.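

In this assay, the change from 4-methylphenyl to cyclobutyl on the carbonyl carbon gives a number 4.2 percentage points higher from compound 3 to compound 4 (within the scatter) so these two groups cannot be told apart here, even though one ring is aromatic and the other is not. Cyclobutyl does not match ethyl at this position, with a number 16 percentage points lower from compound 2 to compound 4 (beyond the scatter) so a small saturated group on the carbonyl carbon does not by itself reach the number of compound 2, while a number 46.2 percentage points higher from compound 1 to compound 4 (beyond the scatter) places cyclobutyl clearly apart from 4-(trifluoromethyl)phenyl. No evidence at hand accounts for these differences.

On these data alone, whether a longer chain such as butyl, a smaller ring such as cyclopropyl, or a chain carrying an amine on this carbonyl carbon would come nearer to compound 2 remains open. The compounds shown also leave open how changes elsewhere on the shared core would affect these numbers.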